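The source may report more compounds than this note shows. Statements on the series, on what has been measured and on what is new or still open speak of the compounds shown alone.

Measured in a functional assay on HCT-116 cells (Homo sapiens) for antiproliferative activity, read by MTT assay, with a stated time of 72 h; on this read-out higher numbers stand for weaker inhibition and lower numbers for stronger inhibition:
- Compound 1 `NC1=NC2(CCOCC2)N(OCCCOc2ccccc2)C(N)=N1`: 6010 nM
- Compound 2 `COc1ccc(OCCCON2C(N)=NC(N)=NC23CCOCC3)cc1`: 1500 nM
- Compound 3 `NC1=NC2(CCOCC2)N(OCCCOc2cccc(Cl)c2Cl)C(N)=N1`: 5 nM

Compound 3 holds the lowest number of the three, and so the strongest inhibition. Compound 4 `NC1=NC2(CCOCC2)N(OCCCOc2ccccc2Cl)C(N)=N1` differs from it by hydrogen in place of chloro on an aromatic carbon, which is hydrogen in place of chloro on an aromatic carbon, turning 2,3-dichlorophenyl into 2-chlorophenyl. Among the compounds with values here, no measured step isolates this change. The closest is the large 1200-fold lower number from compound 1 to compound 3 (3.08 log units; beyond the scatter), which replaces phenyl with 2,3-dichlorophenyl. The equally large a 300-fold lower number from compound 2 to compound 3 (2.48 log units; beyond the scatter) bears less directly, and the modest 4.0-fold lower number from compound 1 to compound 2 (0.60 log units; beyond the scatter) concerns methoxy. Since 2-chlorophenyl lies structurally between phenyl and 2,3-dichlorophenyl, a large step towards a higher number is expected, covering part of that span. The expected step is a 30-fold higher number from compound 3 to compound 4 (1.48 log units; beyond the scatter). Compound 4 is estimated at 150 nM, with an expected range of 30 nM to 800 nM.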

Compound 4, half-maximal inhibitory concentration: 70 nM
Compound 4: the middle estimate sits 2.1-fold (0.33 log units) above what was measured; the measured number falls inside the stated range.
By their numbers in this assay, from the lowest: compound 3; then compound 4; then compound 2; then compound 1.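

In this assay, the chloro group at this position carries weight of its own within 2,3-dichlorophenyl: losing it gives a 14-fold higher number from compound 3 to compound 4 (1.15 log units; beyond the scatter), yet the chloro that remains still gives an 86-fold lower number from compound 1 to compound 4 (1.93 log units; beyond the scatter), so neither chloro group is idle. Even the single chloro of 2-chlorophenyl goes well past 4-methoxyphenyl, with a 21-fold lower number from compound 2 to compound 4 (1.33 log units; beyond the scatter). Nothing available explains these steps. Going by these compounds, whether 3-chlorophenyl alone, or a bromo group or an amine in place of this chloro, would give a comparable step stays open.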